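This account rests on a few compounds, and the source may have more. Where it says the series, first, only, none or still open, it means among the compounds named here.

Compound 3 `CC(=O)N1CCOC(CNC(=O)c2ccncc2Nc2cc(-c3ccc4ccn(C)c4c3)c3nccnc3c2)C1` gives 93 nM in an assay for inhibition of 6-phosphofructo-2-kinase/fructose-2,6-bisphosphatase 3 (Homo sapiens), read by ADP-Glo, with a stated time of 2 h (a higher number here means a weaker inhibitor, a lower number a stronger inhibitor), the highest of the three numbers measured. Compound 1 `CC(=O)N1CCC(NC(=O)c2ccncc2Nc2cc(-c3ccc4ccn(C)c4c3)c3nccnc3c2)CC1` gives 18 nM in this assay, and compound 2 `CN1CCC(NC(=O)c2ccncc2Nc2cc(-c3ccc4ccn(C)c4c3)c3nccnc3c2)CC1=O` gives 41 nM. The measured steps are all modest: a 2.3-fold higher number from compound 1 to compound 2 (0.36 log units; beyond the scatter), a 5.2-fold higher number from compound 1 to compound 3 (0.71 log units; beyond the scatter) and a 2.3-fold higher number from compound 2 to compound 3 (0.36 log units; beyond the scatter). Each of them changes only the group on the amide-type nitrogen, so they show that this part of the molecule moves the number, but only modestly.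

Compound 4 `CN1CCC(N(C)C(=O)c2ccncc2Nc2cc(-c3ccc4ccn(C)c4c3)c3nccnc3c2)C1` is not yet measured. It differs from compound 3 in one place: methyl(1-methylpyrrolidin-3-yl)amino in place of ((4-acetylmorpholin-2-yl)methyl)amino on a carbonyl carbon. Among the compounds with values here, none of the measured steps removes the hydrogen-bond donor or exchanges the six-membered ring for a five-membered one, so no step bears directly on this change; the measured steps only suggest that changes here stay modest. For compound 4 the number is expected to stay close to that of compound 3, with a 1.6-fold lower number from compound 3 to compound 4 (0.19 log units; within the scatter) as the estimated step, and the estimate is 60 nM, within a range from 15 nM to 250 nM.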

Compound 4, half-maximal inhibitory concentration: 176 nM
The estimate for compound 4 lay 2.9-fold (0.47 log units) below the measured number; the range from low to high includes it.
By their numbers in this assay, from the lowest: compound 1; then compound 2; then compounds 3 and 4 (each within the scatter of the next).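

In this assay the exchange of ((4-acetylmorpholin-2-yl)methyl)amino for methyl(1-methylpyrrolidin-3-yl)amino on the carbonyl carbon gives (a 1.9-fold higher number from compound 3 to compound 4 (0.28 log units; within the scatter)), so removing the hydrogen-bond donor and moving to a five-membered ring, taken together, leave the result indistinguishable from that of compound 3. The same group also widens the measured spread at this position, with (a 4.3-fold higher number from compound 2 to compound 4 (0.63 log units; beyond the scatter)) and (a 9.8-fold higher number from compound 1 to compound 4 (0.99 log units; beyond the scatter)), although both steps are still modest. No measurement available here accounts for these differences.

The methyl on the amide nitrogen and the smaller ring change together, so their separate contributions cannot be told apart. Going by these compounds, how a carboxylic acid or a primary amine on this ring would behave also remains open.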